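The source may report more compounds than this note shows. Statements on the series, on what has been measured and on what is new or still open speak of the compounds shown alone.

Measured so far:
- compound 1, `Oc1ccc(-c2cc(-c3cccnc3)nc(-c3ccccc3Cl)c2)cc1`: "not determined" (no result reported)
- compound 2, `Oc1ccc(-c2cc(-c3cccc(Cl)c3)nc(-c3ccccn3)c2)cc1`: 27900 nM
- compound 3, `Oc1cccc(-c2cc(-c3cccc(Cl)c3)nc(-c3cccs3)c2)c1`: 3410 nM

Compound 1 carries no result in a functional assay on T47D cells (Homo sapiens) for cytotoxicity, read by CCK-8 assay and cell counting, with a stated time of 2 days (on this read-out lower numbers stand for stronger inhibition and higher numbers for weaker inhibition), so it stands on no number in this assay; it is known here by its structure only. Going by the values given here, the two compounds that do carry numbers sit well apart: compound 2 gives 27900 nM and compound 3 gives 3410 nM, both weak on this read-out, and no step between them is computed, so only the two values themselves are taken as read.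

Compound 4, `Oc1ccc(-c2cc(-c3ccco3)nc(-c3ccccc3Cl)c2)cc1`, differs from compound 1 in one place: furan-2-yl in place of pyridin-3-yl on an aromatic carbon. A five-membered aromatic ring with one oxygen enters where a six-membered aromatic ring with one nitrogen leaves, next to the ring nitrogen of the shared core, with the 2-chlorophenyl and 4-hydroxyphenyl groups unchanged.

Among the compounds with values here, with no measured step for the pair and no number for compound 1, no direction for this change can be taken from the series; a shift beyond the usual scatter in this assay is possible in either direction, and the estimate for compound 4 therefore rests on the spread seen in compounds 2 and 3. Compound 4 is expected to give about 10000 nM, with a range from 2000 nM to 50000 nM.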

Compound 4, half-maximal inhibitory concentration: 5480 nM
Compound 4: middle estimate off by 1.8-fold (0.26 log units), on the high side; the measured number falls inside the stated range.
By their numbers in this assay, from the lowest: compounds 3 and 4 (each within the scatter of the next); then compound 2.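

No step can be read for compound 4 in this assay: compound 1 offers no number to set against it, and compound 2 and compound 3 differ from it in more than one place. The compounds shown leave open what furan-2-yl in place of pyridin-3-yl does to the read-out. No evidence bearing on this result is available.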